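Alkoxy chain length at the sulfonyl-flanked position

The compounds below may be only part of what the source reports. "The series", "measured", "known", "first", "only" and "open" are said of these compounds alone.

Compound 1 `Cc1cc(SC(C)C)c(S(C)(=O)=O)cc1C(=O)N=C(N)N` gives 12 nM in a functional assay for inhibition of sodium/hydrogen exchanger (Oryctolagus cuniculus); on this read-out higher numbers stand for weaker inhibition and lower numbers for stronger inhibition. Among the compounds with values here, compound 2 `COc1cc(C)c(C(=O)N=C(N)N)cc1S(C)(=O)=O` gives 16 nM in this assay; the one step measured so far, a 1.3-fold higher number from compound 1 to compound 2 (0.12 log units; within the scatter), stays inside the scatter, so compound 2 sits alongside compound 1 with no separation that can be read. The next compound, compound 3 `Cc1cc(OC(C)C)c(S(C)(=O)=O)cc1C(=O)N=C(N)N`, differs from compound 2 by isopropyl in place of methyl on an oxygen on an aromatic ring. Within the data shown here, only the step from compound 1 to compound 2 bears on this change: it traded a three-carbon chain on sulfur for a one-carbon chain on oxygen and moved the number by a 1.3-fold higher number from compound 1 to compound 2 (0.12 log units; within the scatter), that is, by nothing beyond the scatter. Restoring a three-carbon chain, now on oxygen, is therefore expected to give a step of about a 1.1-fold lower number from compound 2 to compound 3 (0.06 log units; within the scatter) in this assay, without clear direction. Compound 3 is estimated at 14 nM, within a range from 6 nM to 35 nM.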

Compound 3, half-maximal inhibitory concentration: 19 nM
Compound 3: middle estimate off by 1.4-fold (0.13 log units), on the low side; the measured number falls inside the stated range.
By their numbers in this assay, from the lowest: compounds 1, 2 and 3 (each within the scatter of the next).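

In this assay the methoxy to isopropoxy change gives a 1.2-fold higher number from compound 2 to compound 3 (0.07 log units; within the scatter) and so shows that, on this oxygen on an aromatic ring, isopropyl in place of methyl brings no readable change. With the isopropyl held constant, the exchange of sulfur for oxygen gives a 1.6-fold higher number from compound 1 to compound 3 (0.20 log units; within the scatter), so this step separates that exchange from the chain-length change mixed into the step from compound 1 to compound 2, and it also stays inside the scatter. No measurement on hand offers an explanation for these results.

Going by these compounds, whether this lack of separation extends to a longer chain such as butoxy, or to an amine or a carboxylic acid on that aromatic carbon, stays open. With compounds 1, 2 and 3 all within the scatter of one another, the limits of what this position tolerates also remain undefined.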